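Benzyl for phenyl on a five-membered aromatic ring

The source may hold more compounds than are shown below. What is called first, only, known or untested is meant among the compounds shown, and "the series" means these compounds.

Measured so far:
Compound 1, `O=C1NC(=O)/C(=C/c2ccc(OCCSc3nnc(-c4ccc(Cl)cc4)[nH]3)cc2)S1` — 16%
Compound 2, `O=C1NC(=O)/C(=C/c2ccc(OCCSc3nnc(-c4ccccc4)o3)cc2)S1` — 11.6%

Among the compounds with values here, only two compounds have been tested in a functional assay on the whole organism (plasma, strain Wistar) with Rattus norvegicus as the target, with a stated time of 15 days, at a dose of 3 mg/kg by the oral route; a higher number here means a stronger effect of the compound at the dose given, a lower number a weaker effect. Compound 1 gives 16% in this assay, and compound 2 gives 11.6%. The gap between the two values lies within the scatter of the assay, so compound 2 and compound 1 cannot be told apart on these numbers; both sit at a modest level of activity. Within the data shown here, no pair that differs in one place has been measured, so no single change has yet been sized.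

The next compound, compound 3, `O=C1NC(=O)/C(=C/c2ccc(OCCSc3nnc(Cc4ccccc4)o3)cc2)S1`, differs from compound 2 in one place: benzyl in place of phenyl on an aromatic carbon. In words, it carries a benzyl in place of a phenyl on an aromatic carbon of the shared core. Among the measured compounds shown here, with no measured step of any kind to lean on, the expectation for this change in this assay is a step of no size beyond the scatter, in either direction. Compound 3 is therefore expected to give about 12% in this assay, within a range from 3% to 24%, which means an expected step of a number 0.4 percentage points higher from compound 2 to compound 3 (within the scatter).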

Compound 3, a percentage reported as activity, at one dose (the size of the read-out at that dose, not a potency): 14.2%
Estimate against measurement, compound 3: 2.2 percentage points below, and the stated range covers the measured number.
By their numbers in this assay, from the lowest: compounds 2, 3 and 1 (each within the scatter of the next).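

Setting benzyl in place of phenyl gives the first single change that can be sized in this assay, and it amounts to a number 2.6 percentage points higher from compound 2 to compound 3 (within the scatter). On this aromatic carbon of the five-membered aromatic ring with 2 nitrogen and 1 oxygen, compound 3 with its benzyl therefore cannot be told apart from compound 2 with its phenyl, so this read-out at this dose does not separate the directly attached ring from the one carried on a single carbon. No measured evidence bears on this result, so it stays an observation without an explanation.

The compounds shown leave open whether a longer chain such as phenethyl, or a group of another kind such as an amine or a carboxylic acid on this carbon, would move the number beyond the scatter. They also leave the part played by the five-membered ring itself unsized, since compound 1 differs from compound 2 in more than one place and the two cannot be compared directly.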